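This account rests on a few compounds, and the source may have more. Where it says the series, first, only, none or still open, it means among the compounds named here.

Measured in an assay on isolated protein for inhibition of glutathione S-transferase P (Homo sapiens), read by spectrophotometry, with a stated time of 3 min; a lower number here means a stronger inhibitor, a higher number a weaker inhibitor:
compound 1 `CCCCCCCCCCO[C@H]1C=C(COC(C)=O)C(=O)[C@H](O)[C@H]1O` — 25300 nM
compound 2 `CCCCCCCCCCO[C@H]1C=C(COC(C)=O)C(=O)[C@@H]2O[C@@](C)(OC)[C@](C)(OC)O[C@@H]12` — 36500 nM

Compound 2 shows the higher of the two numbers recorded in this assay, but its gap to compound 1 lies within the usual scatter of repeated measurements, so the two cannot be told apart on these data. Compound 3 `CO[C@H]1C=C(COC(C)=O)C(=O)[C@@H]2O[C@@](C)(OC)[C@](C)(OC)O[C@@H]12` differs from compound 2 in one place: hydrogen in place of nonyl on a saturated chain carbon bound to an oxygen on a saturated carbon. Among the measured compounds shown here, no step between measured compounds bears on this change, since both compounds measured so far carry the decyloxy group, and nothing here tells what the chain contributes. The expectation for compound 3 is therefore cautious: a modest move toward a higher number in this assay, plausibly beyond the scatter but not large, is expected, and compound 3 is estimated at 70000 nM, within a range from 25000 nM to 200000 nM. This corresponds to an expected step of a 1.9-fold higher number from compound 2 to compound 3 (0.28 log units; within the scatter).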

Compound 3, half-maximal inhibitory concentration: 62700 nM
For compound 3 the middle estimate is 1.1-fold (0.05 log units) above the measured one; measured number inside the range.
By their numbers in this assay, from the lowest: compounds 1, 2 and 3 (each within the scatter of the next, the first and the last beyond it).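

In this assay, replacing the decyloxy group with methoxy gives a 1.7-fold higher number from compound 2 to compound 3 (0.23 log units; within the scatter). Among the compounds shown here, this is the first reading on this chain, and it shows that removing nonyl from the saturated chain carbon bound to an oxygen leaves a difference too small to resolve on this core, so the full decyl chain cannot be said to matter here. No independent measurement on hand accounts for this result.

The compounds shown leave open whether a chain of intermediate length such as hexyl, a longer chain, or a decyl chain ending in an amine or a carboxylic acid would read differently. They also leave open whether the same change would read alike on the core of compound 1.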